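Trimethoxyphenyl for fluorophenyl on the shared core

The source may report more compounds than this note shows. Statements on the series, on what has been measured and on what is new or still open speak of the compounds shown alone.

Measured so far:
compound 1 `COc1cc(-c2cc(C(=O)Nc3nc4ccc(Cl)cc4s3)nc3cc(-c4ccccc4)nn23)cc(OC)c1OC` gives 22400 nM in a functional assay on HeLa cells (Homo sapiens) for cytotoxicity, read by MTT assay, with a stated time of 48 h; on this read-out higher numbers stand for weaker inhibition and lower numbers for stronger inhibition
compound 2 `COc1cc(-c2cc(C(=O)Nc3nc4ccc(F)cc4s3)nc3cc(-c4ccccc4)nn23)cc(OC)c1OC` gives 25100 nM in this assay
compound 3 `COc1ccc2nc(NC(=O)c3cc(-c4ccc(F)cc4)n4nc(-c5ccccc5)cc4n3)sc2c1` gives 17300 nM in this assay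

The three numbers fall within the scatter of one another, so compound 3 cannot be told apart from compound 1 or compound 2 on this read-out. Within the data shown here, the only single-point step among the measured compounds, a 1.1-fold higher number from compound 1 to compound 2 (0.05 log units; within the scatter), concerns the benzothiazole halogen and is within the scatter.

Compound 4 `COc1ccc2nc(NC(=O)c3cc(-c4cc(OC)c(OC)c(OC)c4)n4nc(-c5ccccc5)cc4n3)sc2c1` differs from compound 3 by 3,4,5-trimethoxyphenyl in place of 4-fluorophenyl on an aromatic carbon. Among the measured compounds shown here, no measured pair isolates this change. What the data do offer is that compound 1 and compound 2 already carry the 3,4,5-trimethoxyphenyl group and give numbers within the scatter of compound 3, which carries the 4-fluorophenyl group. Nothing in the set therefore points to a step beyond the scatter in either direction.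

For compound 4 the expected step is a 1.2-fold higher number from compound 3 to compound 4 (0.06 log units; within the scatter), meaning no change beyond the scatter. The estimate for compound 4 in this assay is 20000 nM, with a range from 9000 nM to 45000 nM.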

Compound 4, half-maximal inhibitory concentration: 8700 nM
The estimate for compound 4 lay 2.3-fold (0.36 log units) above the measured number, and the stated range ends above it.
By their numbers in this assay, from the lowest: compounds 4, 3, 1 and 2 (each within the scatter of the next, the first and the last beyond it).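

At the aromatic carbon next to the ring nitrogen, 3,4,5-trimethoxyphenyl in place of 4-fluorophenyl now has a direct reading in this assay, and a 2.0-fold lower number from compound 3 to compound 4 (0.30 log units; within the scatter) shows that the larger group is accepted there without a loss, though the step does not establish a gain. Among these compounds, with 3,4,5-trimethoxyphenyl held constant, the other end of the molecule gives the first steps beyond the scatter, both modest: methoxy in place of chloro gives a 2.6-fold lower number from compound 1 to compound 4 (0.41 log units; beyond the scatter) and methoxy in place of fluoro gives a 2.9-fold lower number from compound 2 to compound 4 (0.46 log units; beyond the scatter), whereas the earlier exchange of one halogen for the other gave nothing beyond the scatter. Nothing available accounts for either the tolerance at the first position or the modest steps at the second.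

The compounds shown leave open whether an amine or a carboxylic acid on the phenyl ring at this position, or a lone methoxy group there, would move the number beyond the scatter. Also open, from the compounds shown here alone, is whether methoxy in place of a halogen gives a similar step with 4-fluorophenyl on the shared core.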